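Extending the ring nitrogen substituent of compound 3

The source may report more compounds than this note shows. Statements on the series, on what has been measured and on what is new or still open speak of the compounds shown alone.

Three compounds share one core and differ only in what the ring nitrogen carries. Compound 1, `C=CCCN1CCC(CCCn2c(COc3ccccc3)nc3c(OCCCN4CCCCC4)cccc32)CC1`, gives 0.707 nM in an in vitro assay on AV12 cells for binding affinity to Neuropeptide Y receptor type 1 (Homo sapiens); a lower number here means a stronger inhibitor, a higher number a weaker inhibitor. Compound 2, `c1ccc(OCc2nc3c(OCCCN4CCCCC4)cccc3n2CCCC2CCN(CCCN3CCCCC3)CC2)cc1`, gives 0.106 nM. Compound 3, `CN1CCC(CCCn2c(COc3ccccc3)nc3c(OCCCN4CCCCC4)cccc32)CC1`, gives 1.62 nM, the highest of the three numbers and thus the weakest binder here, since a 2.3-fold higher number from compound 1 to compound 3 (0.36 log units; beyond the scatter) and a 15-fold higher number from compound 2 to compound 3 (1.18 log units; beyond the scatter) both fall beyond the scatter.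

Compound 4, `O=C(CCN1CCC(CCCn2c(COc3ccccc3)nc3c(OCCCN4CCCCC4)cccc32)CC1)c1ccccc1`, is not yet measured. Its difference from compound 3 is benzoylmethyl in place of hydrogen on a saturated chain carbon bound to an amine nitrogen in a ring. The two measured steps onto compound 3 bear on this: a small group in place of hydrogen at that carbon moved the number modestly, while a longer chain ending in a ring moved it a good deal further. The benzoylmethyl group in compound 4 is of intermediate size and carries a ring, so a lowering of the number beyond the scatter is expected, likely between those two steps in size. For compound 4 the expected step is a 3.2-fold lower number from compound 3 to compound 4 (0.51 log units; beyond the scatter), giving an estimate of 0.5 nM, with a range from 0.15 nM to 1.6 nM.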

Compound 4, inhibition constant: 0.112 nM
Compound 4: the middle estimate sits 4.5-fold (0.65 log units) above what was measured; the measured number lies below the stated range.
By their numbers in this assay, from the lowest: compounds 2 and 4 (each within the scatter of the next); then compound 1; then compound 3.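

In this assay, only the chain ending in a piperidine had produced a large step before, and a 14-fold lower number from compound 3 to compound 4 (1.16 log units; beyond the scatter) shows that a step of this size at this position does not require that amine, as the benzoylmethyl group contains only carbon and oxygen. The two end groups cannot be told apart here: with a 1.1-fold higher number from compound 2 to compound 4 (0.02 log units; within the scatter), benzoyl and (piperidin-1-yl)methyl give numbers within the scatter of each other, despite their different atoms. Chain presence alone does not set the number either, as a 6.3-fold lower number from compound 1 to compound 4 (0.80 log units; beyond the scatter) comes from benzoyl in place of vinyl at the same place on the chain, so what ends the chain matters.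

The compounds shown offer no measurement that explains any of these steps. As far as these compounds go, it remains open whether the carbonyl itself contributes, which an alcohol in its place could test, and whether a longer chain before the benzoyl group, or a carboxylic acid at the chain end, would keep the number at the level of compound 2 and compound 4.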